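A Methyl Added to the Phenyl Ring of Compound 2

The source may report more compounds than this note shows. Statements on the series, on what has been measured and on what is new or still open speak of the compounds shown alone.

Of the compounds shown here, two from this series have so far been tested in a functional assay on the whole organism for inhibition of sodium-dependent dopamine transporter (Mus musculus); a lower number here means that less compound is needed, a higher number that more compound is needed for the effect. Compound 1 `Cc1ccc(C2CN(C)Cc3c(N)cccc32)cc1` gives about 22 mg/kg in this assay. Compound 2 `CCCCNCC(=O)Nc1cccc2c1CN(C)CC2c1ccccc1` gives 25 mg/kg in this assay, and the gap between these two numbers lies within the usual scatter of repeated measurements, so the two compounds stand side by side with no ranking between them. Compound 3 `CCCCNCC(=O)Nc1cccc2c1CN(C)CC2c1ccc(C)cc1` has not yet been measured. It is built from compound 2 by one change: methyl in place of hydrogen on an aromatic carbon. Among the measured compounds shown here, no pair of measured compounds differs by just this change, so its effect on the dose cannot be read from the data at hand. On that basis the expected step of a 1.3-fold lower number from compound 2 to compound 3 (0.10 log units; within the scatter) is small and stays within the scatter. The estimate for compound 3 in this assay is 20 mg/kg, with a range from 8 mg/kg to 50 mg/kg.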

Compound 3, dose for half-maximal effect: 14 mg/kg
Compound 3: middle estimate off by 1.4-fold (0.15 log units), on the high side; the measured number falls inside the stated range.
By their numbers in this assay, from the lowest: compounds 3, 1 and 2 (each within the scatter of the next).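

In this assay, among the compounds shown here, changing phenyl to 4-methylphenyl gives a 1.8-fold lower number from compound 2 to compound 3 (0.25 log units; within the scatter) and is the first direct reading of this change, showing that a methyl on this aromatic carbon, para to a large group, leaves the dose within the usual spread. Compound 1 already carries the 4-methylphenyl, and placing ((butylamino)methyl)carbonyl on its nitrogen gives a 1.6-fold lower number from compound 1 to compound 3 (0.20 log units; within the scatter) and so shows that the methyl and this side chain can stand together without a clear shift in dose. Nothing measured here accounts for either step.

A single small group at one place cannot show whether the dose would stay in this range with a larger or different group there, such as a methoxy group, a chlorine or an amine. Going by these compounds, it also remains open whether a longer chain at the same carbon would give a step beyond the scatter.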